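The source may hold more compounds than are shown below. What is called first, only, known or untested is meant among the compounds shown, and "the series" means these compounds.

Measured compounds:
Compound 1, `O=C1C=C(N2CCC2)C(=O)c2c1nc1n2[C@H]2OC[C@@H](O)[C@H]2OC1`: in a functional assay on HeLa cells (Homo sapiens) for inhibition, read by sulforhodamine B assay (on this read-out lower numbers stand for stronger inhibition and higher numbers for weaker inhibition), compound 1 gives > 16000 nM, which is a limit of the assay.
Compound 2, `O=C1C=C(NC2CCCC2)C(=O)c2c1nc1n2[C@H]2OC[C@@H](O)[C@H]2OC1`: compound 2 gives > 16000 nM, again a limit of the assay.
Compound 3, `O=C1C=C(Nc2ccc(Br)cc2)C(=O)c2c1nc1n2[C@H]2OC[C@@H](O)[C@H]2OC1`: compound 3 gives 3830 nM.

Compound 3 is therefore the only one of the three with a real number; the other two sit at the limit of > 16000 nM in this assay, at which 2 of the 3 values shown sit. From the two compounds carrying a saturated ring on the ring carbon to compound 3 the number falls by an at least 4.1-fold lower number from compound 1 to compound 3 (0.62 log units; beyond the scatter) and by an at least 4.1-fold lower number from compound 2 to compound 3 (0.62 log units; beyond the scatter), while the step that the two limits leave unreadable from compound 1 to compound 2 stays unreadable. Compound 4, `COc1ccc(NC2=CC(=O)c3nc4n(c3C2=O)[C@H]2OC[C@@H](O)[C@H]2OC4)cc1`, differs from compound 3 only in methoxy in place of bromo on an aromatic carbon. No measured step touches this exchange: the steps shown set an aromatic ring against saturated ones, not one aromatic substituent against another. The account therefore expects no change beyond the scatter for compound 4, with the step from compound 3 estimated as a 1.3-fold higher number from compound 3 to compound 4 (0.12 log units; within the scatter). Compound 4 is estimated at 5000 nM, between 1500 nM and 16000 nM, with a fair chance that only a limit is returned.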

Compound 4, half-maximal inhibitory concentration: 4780 nM
Estimate against measurement, compound 4: 1.0-fold (0.02 log units) above; the range from low to high includes it.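

In this assay, putting methoxy in place of bromo on the aromatic carbon para to a large group gives a 1.2-fold higher number from compound 3 to compound 4 (0.10 log units; within the scatter), so the two groups are not told apart at this position. The advantage of an aromatic ring on the amine nitrogen therefore no longer rests on compound 3 alone, since the methoxy compound also stands clear of the saturated rings, with an at least 3.3-fold lower number from compound 2 to compound 4 (0.52 log units; beyond the scatter) and an at least 3.3-fold lower number from compound 1 to compound 4 (0.52 log units; beyond the scatter). The step between compound 1 and compound 2 still cannot be read, as both compounds remain at a limit: the limit of > 16000 nM in this assay, at which 2 of the 4 values shown sit.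

The compounds shown hold only bromo and methoxy at this place, so it stays open whether a carboxylic acid, an amine or a longer alkoxy chain there would leave the number in this assay unchanged. Also open, as far as these compounds go, is whether an unsubstituted phenyl on the amine nitrogen would read like compound 3 and compound 4.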